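A few compounds are considered here, and "the series" means these few. Any claim that something is new, unique, unknown or untested is made for them only; others in the source may bear on it.

Compounds measured in this assay:
compound 1, `Nc1ncnc2c1c(-c1cc(C3CC3)on1)nn2C1CCOCC1`: 940 nM
compound 2, `CCCCCCCn1nc(-c2cc(C3CC3)on2)c2c(N)ncnc21`: > 10000 nM
compound 3, `CC(C)n1nc(-c2ccon2)c2c(N)ncnc21`: 7920 nM

In an assay on TT cells for inhibition of proto-oncogene tyrosine-protein kinase receptor Ret variant C634W (Homo sapiens), read by MTT assay, with a stated time of 10 days (on this read-out lower numbers stand for stronger inhibition of growth and higher numbers for weaker inhibition of growth), compound 1 gives 940 nM. Compound 3 gives 7920 nM. For compound 2 the assay returns a limit and no number, > 10000 nM, so on the numbers shown compound 2 stands only at that limit (the limit of > 10000 nM in this assay, at which 1 of the 3 values shown sits). Within the data shown here, the single step between measured compounds that differ in one place is an at least 10-fold higher number from compound 1 to compound 2 (1.02 log units; beyond the scatter), heptyl in place of oxan-4-yl on an aromatic nitrogen.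

The compound still to be measured is compound 4, `Cn1nc(-c2cc(C3CC3)on2)c2c(N)ncnc21`. Against compound 2 the difference is hydrogen in place of hexyl on a saturated chain carbon bound to an aromatic nitrogen; cut one bond further out, this reads heptyl to methyl. Among the measured compounds shown here, the only measured step that bears on it is the one from compound 1 to compound 2, which was large and ran toward weaker inhibition of growth as the heptyl entered. For the measured compounds named here, compound 3 carries an isopropyl on the same nitrogen but also lacks the cyclopropyl of compound 2, so its value shows only that a short group on that nitrogen is compatible with a measurable number. Shortening heptyl to methyl is therefore expected to move the number back downward, an at least 3.3-fold lower number from compound 2 to compound 4 (0.52 log units; beyond the scatter), though from a limit the size is uncertain. Compound 4 is estimated at 3000 nM, within 900 nM to 10000 nM.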

Compound 4, concentration for 50% growth inhibition: 3510 nM
For compound 4 the middle estimate is 1.2-fold (0.07 log units) below the measured one, and the stated range covers the measured number.
By their numbers in this assay, from the lowest: compound 1; then compound 4; then compound 3. At a limit, above all of these: compound 2.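

In this assay, heptyl cut back to methyl on the aromatic nitrogen gives a clear recovery (an at least 2.8-fold lower number from compound 2 to compound 4 (0.45 log units; beyond the scatter)), so the weak growth inhibition with heptyl is not shared by every alkyl group at this place. Methyl does not reach the level of oxan-4-yl (a 3.7-fold higher number from compound 1 to compound 4 (0.57 log units; beyond the scatter)), which puts the three groups on this nitrogen, with the rest of the structure held constant, in the order oxan-4-yl, methyl, heptyl, from stronger to weaker inhibition of growth. Compound 2 remains a limit and not a number, so the full size of the heptyl effect stays unknown: the limit of > 10000 nM in this assay, at which 1 of the 4 values shown sits.

Chains of intermediate length, such as propyl or butyl, would show whether the number climbs gradually from methyl to heptyl or changes abruptly, and a chain ending in an amine or a hydroxyl group would test whether oxan-4-yl's advantage depends on its ring or its oxygen. Compound 3 differs from compound 4 in two places, so the isopropyl group and the cyclopropyl group cannot be assessed separately from its value.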